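Benzylamine series: compound 2 to compound 3

The source may report more compounds than this note shows. Statements on the series, on what has been measured and on what is new or still open speak of the compounds shown alone.

Measured so far:
- compound 1, `COc1cc(CNCc2ccncc2)ccc1OCc1cccc(F)c1`: 4800 nM
- compound 2, `COc1cc(CNCC2CCCO2)ccc1OCc1ccc(Cl)nc1`: 66000 nM

In a functional assay on HeLa cells (Homo sapiens) for inhibition, with a stated time of 72 h (a lower number here means that less compound is needed, a higher number that more compound is needed for the effect), compound 2 gives 66000 nM, the highest of the two numbers recorded. Among the measured compounds shown here, the nearest measured compound is compound 1, which in this assay gives 4800 nM, a gap well beyond the scatter; the two differ in more than one place, so the two values are simply noted side by side and no single step is drawn between them.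

Compound 3, `COc1cc(CNc2nc[nH]n2)ccc1OCc1ccc(Cl)nc1`, is the next compound to be measured. It keeps the rest of compound 2 unchanged and differs only on the amine nitrogen: 1H-1,2,4-triazol-3-yl in place of (oxolan-2-yl)methyl on an amine nitrogen

For the measured compounds named here, no step between measured compounds covers this change, so the size and direction of the step from compound 2 to compound 3 are not known from the data. The expectation is a moderate movement toward a lower number, a 1.9-fold lower number from compound 2 to compound 3 (0.28 log units; within the scatter), though a step of either direction within the scatter cannot be ruled out. For compound 3 the estimate in this assay is 35000 nM, with a range from 8000 nM to 150000 nM.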

Compound 3, half-maximal effective concentration: 69000 nM
Beside the measured number, compound 3's estimate is 2.0-fold (0.29 log units) below it; the range from low to high includes it.
By their numbers in this assay, from the lowest: compound 1; then compounds 2 and 3 (each within the scatter of the next).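

In this assay, among the compounds shown here, the exchange of (oxolan-2-yl)methyl for 1H-1,2,4-triazol-3-yl on the amine nitrogen gives the first single-place step: a 1.0-fold higher number from compound 2 to compound 3 (0.02 log units; within the scatter). At this position, a five-membered non-aromatic ring with 1 hetero atom and a five-membered aromatic ring with 3 hetero atoms therefore give numbers that cannot be told apart, even though the groups also differ in hydrogen-bond donors, 0 against 1, and in hydrogen-bond acceptors, 1 against 2. No measurement at hand bears on why these two groups read alike in this assay.

Compound 1 gives 4800 nM but differs from compound 2 in more than one place, so the compounds shown do not tell whether a change on the amine nitrogen alone can reach a number of that size. Also open, going by these compounds, is how a longer saturated chain or a carboxylic acid on that amine nitrogen would read in this assay, with the rest of compound 2 held constant.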